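The source may hold more compounds than are shown below. What is called first, only, known or untested is meant among the compounds shown, and "the series" means these compounds.

Compounds measured so far in an ADME assay on MT2 cells (Homo sapiens) for cytotoxicity, read by MTT assay; a higher number here means that more compound is tolerated, a lower number that less compound is tolerated:

- compound 1 `Clc1cccc(Cl)c1Cc1nnc(Nc2ccc(COCc3ccsc3)cc2)o1`: > 100000 nM.
- compound 2 `O=c1ncccn1SCCc1ccc(Nc2ncc(Cc3c(F)cccc3F)o2)cc1`: > 100000 nM.
- compound 3 `Clc1cccc(Cl)c1Cc1nnc(Nc2ccc(COCc3ccco3)cc2)o1`: 12000 nM.

For compound 1 the value is only a limit of the assay, > 100000 nM. For compound 2 the value is likewise only a limit, > 100000 nM. Compound 3 gives a real number, 12000 nM. For the measured compounds named here, the one step between measured compounds that differ in a single place is an at least 8.3-fold lower number from compound 1 to compound 3 (0.92 log units; beyond the scatter), so the compound carrying the furan group is the only one tolerated at a measurable concentration.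

Compound 2 therefore stands at the limit of > 100000 nM in this assay, at which 2 of the 3 values shown sit; nothing more than that is known of it.

The next compound is compound 4 `Fc1cccc(F)c1Cc1cnc(Nc2ccc(COCc3ccco3)cc2)o1`. It differs from compound 2 in that (a group of 7 heavy atoms (5 carbon, 2 oxygen; one five-membered aromatic ring with 1 hetero atom) in place of a group of 9 heavy atoms (5 carbon, 2 nitrogen, 1 oxygen, 1 sulfur; one six-membered aromatic ring with 2 hetero atoms), on a saturated chain carbon bound to an aromatic carbon). Going by the values given here, no measured step covers exactly this change. The closest guide is the step from compound 1 to compound 3, which also brought in a furan-2-yl group and lowered the number beyond the scatter. Compound 4 shares its (furan-2-yl)methoxy group with compound 3, whose value was 12000 nM. Compound 4 is therefore expected to give a number rather than a limit, estimated at 30000 nM, within 8000 nM to 100000 nM. That estimate would mean a step of an at least 3.3-fold lower number from compound 2 to compound 4 (0.52 log units; beyond the scatter).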

Compound 4, half-maximal cytotoxic concentration: 31000 nM
Compound 4: middle estimate off by 1.0-fold (0.01 log units), on the low side; low and high end bracket the measured number.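

Putting (furan-2-yl)methoxy on a saturated chain carbon bound to an aromatic carbon, in place of the group of 9 heavy atoms with its six-membered aromatic ring, gives an at least 3.2-fold lower number from compound 2 to compound 4 (0.50 log units; beyond the scatter) in this assay. The lower number that came with a furan-2-yl group in an at least 8.3-fold lower number from compound 1 to compound 3 (0.92 log units; beyond the scatter) is therefore not confined to one core: it recurs in a second pair, where a different group leaves. The true size of the new step remains unknown, as compound 2 has only an assay limit and not a number: the limit of > 100000 nM in this assay, at which 2 of the 4 values shown sit.

Still open, as far as these compounds go, is whether the furan-2-yl ring itself lowers the number on the core of compound 4, or whether the departing group matters more. Also open, from the compounds shown here alone, is how an amine or a carboxylic acid at this place would read.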